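The compounds below may be only part of what the source reports. "The series", "measured", "known", "first", "only" and "open" are said of these compounds alone.

Measured so far:
compound 1 `COc1ccc2cc(C(C)c3nnc4n3N=C(c3ccc(Cl)cc3Cl)CS4)ccc2c1` — 14600 nM
compound 2 `CC(c1ccc(-c2ccccc2)c(F)c1)c1nnc2n1N=C(c1ccc(Cl)cc1Cl)CS2` — 7600 nM

In a functional assay on MCF7 cells (Homo sapiens) for inhibition, read by sulforhodamine B assay, with a stated time of 72 h (a higher number here means a weaker inhibitor, a lower number a stronger inhibitor), compound 1 gives 14600 nM, the highest of the two numbers; compound 2 gives 7600 nM, and the two values lie within the scatter of each other, so no order between them is claimed. Compound 3 `COc1ccc2cc(C(C)c3nnc4n3N=C(c3ccc(Cl)cc3)CS4)ccc2c1` is the next entry and is still to be measured. It differs from compound 1 by hydrogen in place of chloro on an aromatic carbon. For the measured compounds named here, no step between measured compounds bears on this change, so the expectation rests on compound 1 alone. A small shift toward a weaker inhibitor, close to the scatter, is expected, a 1.4-fold higher number from compound 1 to compound 3 (0.14 log units; within the scatter). For compound 3 the estimate is 20000 nM, with a range from 8000 nM to 50000 nM.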

Compound 3, half-maximal inhibitory concentration: 10100 nM
Compound 3: middle estimate off by 2.0-fold (0.30 log units), on the high side, within the range that was stated.
By their numbers in this assay, from the lowest: compounds 2, 3 and 1 (each within the scatter of the next).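

In this assay, for the compounds shown here, the first one-place comparison, the change from 2,4-dichlorophenyl to 4-chlorophenyl gives a 1.4-fold lower number from compound 1 to compound 3 (0.16 log units; within the scatter), so at this position, ortho to a large group, chloro and hydrogen cannot be told apart. No measurement bears on a cause for this step.

Still open, going by these compounds, is whether an amine or a carboxylic acid on this aromatic carbon would give a step beyond the scatter. The compounds shown also leave open what replacing the remaining chloro group with hydrogen or an amine would do.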